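From Ethoxycarbonyl to Benzyloxycarbonyl on a Shared Core

The source may report more compounds than this note shows. Statements on the series, on what has been measured and on what is new or still open speak of the compounds shown alone.

In a functional assay on HeLa cells (Homo sapiens) for antiproliferative activity, read by MTT assay, with a stated time of 48 h (a higher number here means a weaker inhibitor of growth, a lower number a stronger inhibitor of growth), compound 2 `COC(=O)N1N=C(c2cccc(O)c2)CC1c1cc(OC)c(OC)c(OC)c1` gives 1970 nM and compound 3 `CCOC(=O)N1N=C(c2cccc(O)c2)CC1c1cc(OC)c(OC)c(OC)c1` gives 3280 nM, so compound 3 stands level with compound 2 within the scatter. Compound 1 `COc1cccc(C2=NN(C(=O)OCc3ccccc3)C(c3cc(OC)c(OC)c(OC)c3)C2)c1` is reported only as a limit, > 10000 nM. It also carries benzyloxycarbonyl.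

Compound 4 `COc1cc(C2CC(c3cccc(O)c3)=NN2C(=O)OCc2ccccc2)cc(OC)c1OC` departs from compound 3 by phenyl in place of methyl on a saturated chain carbon bound to an oxygen next to a carbonyl group, turning ethoxycarbonyl into benzyloxycarbonyl. Among the compounds with values here, the one measured step at this place, a 1.7-fold higher number from compound 2 to compound 3 (0.22 log units; within the scatter), added only a methyl, so it guides a phenyl change loosely. With compound 1 also in view at > 10000 nM, a modest step toward a higher number is expected: a 2.1-fold higher number from compound 3 to compound 4 (0.33 log units; beyond the scatter). Compound 4 is estimated at 7000 nM, with an expected range of 2500 nM to 20000 nM.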

Compound 4, concentration for 50% growth inhibition: > 10000 nM
Compound 4 was reported as a limit (the forecaster's own chance of this, stated with the estimate: 30%); middle value at least 1.4-fold (0.15 log units) away from the limit.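

In this assay, phenyl in place of methyl at this carbon gives an at least 3.0-fold higher number from compound 3 to compound 4 (0.48 log units; beyond the scatter), and phenyl in place of hydrogen gives an at least 5.0-fold higher number from compound 2 to compound 4 (0.70 log units; beyond the scatter). On these data alone, the methyl step stayed within the scatter, so this position tolerates a small addition, while phenyl produces a change beyond the scatter whose full size remains unknown. Compound 1 and compound 4 both stand at one limit, so the step between them cannot be read: the limit of > 10000 nM in this assay, at which 2 of the 4 values shown sit.

As far as these compounds go, what a longer chain such as propyl, or an amine on the phenyl, would give at this carbon stays open.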